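Methyl for iodo on the aryl of a triazole-linked terpenoid

The compounds below may be only part of what the source reports. "The series", "measured", "known", "first", "only" and "open" are said of these compounds alone.

Measured compounds in an ADME assay on HEK293 cells (Homo sapiens) for cytotoxicity, read by MTT assay, with a stated time of 48 h; a lower number here means a stronger inhibitor, a higher number a weaker inhibitor:
compound 1, `C=C1CC[C@@H](C(C)C)[C@]12CC=C(C=O)CC2`, 550000 nM;
compound 2, `C=C1CCC[C@]2(C)CCC(c3cn(-c4ccc(I)cc4)nn3)=CC[C@@]12C`, 215000 nM;
compound 3, `C=C1CCC[C@]2(C)CCC(c3cn(CC(=O)Nc4ccc(C)cc4)nn3)=CC[C@@]12C`, 622000 nM.

Compound 2 has the lowest number of the three. Compound 1 lies beyond the scatter above it, and compound 3 lies further above it still, also beyond the scatter. Compound 4, `C=C1CCC[C@]2(C)CCC(c3cn(-c4ccc(C)cc4)nn3)=CC[C@@]12C`, has not been measured. It differs from compound 2 in one place: methyl in place of iodo on an aromatic carbon. Among the compounds with values here, with no measured pair showing this same exchange, the expected step in this assay is small and toward a higher number, a change that may still fall within the scatter. Compound 4 is therefore estimated at 350000 nM, between 150000 nM and 800000 nM, which corresponds to an expected step of a 1.6-fold higher number from compound 2 to compound 4 (0.21 log units; within the scatter).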

Compound 4, half-maximal inhibitory concentration: 524000 nM
For compound 4 the middle estimate is 1.5-fold (0.18 log units) below the measured one, and the stated range covers the measured number.
By their numbers in this assay, from the lowest: compound 2; then compounds 4, 1 and 3 (each within the scatter of the next).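

Within the data shown here, the 4-iodophenyl to 4-methylphenyl exchange gives the first comparison in one place in this assay, with a 2.4-fold higher number from compound 2 to compound 4 (0.39 log units; beyond the scatter). It shows that the group on this aromatic carbon, para to a large group, moves the number, even though one heavy atom replaces another and the counted donors and acceptors stay the same. Nothing available speaks to what lies behind this step.

As far as these compounds go, how a hydrogen, a chloro, a methoxy or a carboxylic acid at this position would compare remains open. So does whether the exchange gives a similar step on another core.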